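A few compounds are considered here, and "the series" means these few. Any claim that something is new, unique, unknown or untested is made for them only; others in the source may bear on it.

Compound 1 `COc1ccc(S(=O)(=O)NC2=NCCN2C(=S)SN2CCn3c2nsc3=S)cc1OC`: in a functional assay on KYSE-510 cells (Homo sapiens) for antiproliferative activity, read by crystal violet staining, with a stated time of 96 h (a lower number here means a stronger inhibitor of growth, a higher number a weaker inhibitor of growth), compound 1 gives >= 20000 nM, which is a limit of the assay and not a number.
Compound 2 `O=[N+]([O-])c1ccc(S(=O)(=O)NC2=NCCN2C(=S)SN2CCn3c2nsc3=S)cc1`: in this assay compound 2 gives >= 20000 nM, also a limit of the assay.

Compound 2 therefore stands at the limit of >= 20000 nM in this assay, at which 2 of the 2 values shown sit, so its true potency is not known, only that it lies at or beyond that limit. The next compound, compound 3 `O=S(=O)(NC1=NCCN1C(=S)SN1CCn2c1nsc2=S)c1ccc(Br)cc1`, differs from compound 2 in one place: bromo in place of nitro on an aromatic carbon, on an aromatic carbon of a six-membered aromatic ring of carbon only, para to a large group. Within the data shown here, the only measured step in this assay, a step that the two limits leave unreadable from compound 1 to compound 2, cannot be read because both ends are limits, so no size or direction can be drawn from it. The expectation for compound 3 in this assay is therefore that it again reaches only the limit, estimated at 20000 nM (range 6000 nM to 40000 nM), a step of a number no higher from compound 2 to compound 3 (the limit leaves the size open) that is expected to stay within the scatter.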

Compound 3, concentration for 50% growth inhibition: >= 20000 nM
Compound 3 was reported as a limit; the forecaster's own chance of this, stated with the estimate: 75%; the middle value sits exactly at the limit.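

No step among compound 1, compound 2 and compound 3 can be read, in size or in direction, since all three give only a limit: the limit of >= 20000 nM in this assay, at which 3 of the 3 values shown sit.

The compounds shown leave open how potent each truly is, and whether 3,4-dimethoxyphenyl, 4-nitrophenyl and 4-bromophenyl differ at all in their effect on growth.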